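From tert-butoxy to 2-(1H-indol-3-yl)ethyl on one carbonyl carbon

A few compounds are considered here, and "the series" means these few. Any claim that something is new, unique, unknown or untested is made for them only; others in the source may bear on it.

In a toxicity assay on KB cells (Homo sapiens) for cytotoxicity, read by fluorescence, with a stated time of 3 days (on this read-out higher numbers stand for an effect only at larger amounts of compound and lower numbers for an effect already at smaller amounts), compound 1 `CCCCOC(=O)CNC(=O)[C@H](CSc1ccc([N+](=O)[O-])cc1[N+](=O)[O-])NC(=O)CC[C@H](NC(=O)CCC(C)C)C(=O)OCCCC` gives 84 uM, and compound 2 `CCCCOC(=O)CNC(=O)[C@H](CSc1ccc([N+](=O)[O-])cc1[N+](=O)[O-])NC(=O)CC[C@H](NC(=O)OC(C)(C)C)C(=O)OCCCC` gives 70.4 uM. Going by the values given here, these are the only two numbers so far, and they cannot be told apart: the measured step is a 1.2-fold lower number from compound 1 to compound 2 (0.08 log units; within the scatter), with tert-butoxy in place of isopentyl on a carbonyl carbon.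

Compound 3 `CCCCOC(=O)CNC(=O)[C@H](CSc1ccc([N+](=O)[O-])cc1[N+](=O)[O-])NC(=O)CC[C@H](NC(=O)CCc1c[nH]c2ccccc12)C(=O)OCCCC` has not yet been measured. It carries 2-(1H-indol-3-yl)ethyl in place of tert-butoxy on that same carbonyl carbon: 2-(1H-indol-3-yl)ethyl in place of tert-butoxy on a carbonyl carbon. Among the compounds with values here, the single step from compound 1 to compound 2 is the only guide, and it is a thin one, since the entering group resembles neither group compared there. No shift beyond the scatter is therefore expected, the estimated step being a 1.2-fold lower number from compound 2 to compound 3 (0.07 log units; within the scatter). For compound 3 the estimated value in this assay is 60 uM, with an expected range of 25 uM to 130 uM.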

Compound 3, concentration for half-maximal effect: 26 uM
Beside the measured number, compound 3's estimate is 2.3-fold (0.36 log units) above it, and the stated range covers the measured number.
By their numbers in this assay, from the lowest: compound 3; then compounds 2 and 1 (each within the scatter of the next).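

In this assay this position on the carbonyl carbon now shows a change that stands clear of the scatter, with a 2.7-fold lower number from compound 2 to compound 3 (0.43 log units; beyond the scatter) and with a 3.2-fold lower number from compound 1 to compound 3 (0.51 log units; beyond the scatter) as a second, similar reading. Compound 1 and compound 2 could not be told apart, so changing between isopentyl and tert-butoxy showed nothing, whereas 2-(1H-indol-3-yl)ethyl, with its two aromatic rings and one hydrogen-bond donor, brings a modest shift towards an effect at smaller amounts. Nothing measured here explains why the number moves.

On these data alone, it remains open whether the shift needs the indole ring with its nitrogen hydrogen or would also appear with a plain 2-phenylethyl group. As far as these compounds go, how an amine or a carboxylic acid at the end of a chain on this carbonyl carbon would read also remains unknown.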